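Fluorophenyl positional isomers on the shared core

A few compounds are considered here, and "the series" means these few. Any claim that something is new, unique, unknown or untested is made for them only; others in the source may bear on it.

Measured compounds in a functional assay on MDA-MB-231 cells (Homo sapiens) for cytotoxicity, read by MTT assay, with a stated time of 72 h; on this read-out higher numbers stand for weaker inhibition and lower numbers for stronger inhibition:
compound 1 `COc1cc2c(Oc3ccc(NC(=O)c4nn(-c5cccc(F)c5)c(=O)c5ccccc45)cc3F)ccnc2cc1OCCCN1CCCC1` — 880 nM
compound 2 `COc1cc2c(Oc3ccc(NC(=O)c4nn(-c5ccccc5)c(=O)c5ccccc45)cc3F)ccnc2cc1OCCCN1CCC(C)CC1` — 1480 nM
compound 3 `COc1cc2c(Oc3ccc(NC(=O)c4nn(-c5ccc(F)cc5)c(=O)c5ccccc45)cc3F)ccnc2cc1OCCCN1CCC(C)CC1` — 660 nM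

Within the data shown here, compound 3 gives the lowest number of the three, though its gap to compound 1 is within the scatter; only compound 2 stands clearly apart from it, by a 2.2-fold lower number from compound 2 to compound 3 (0.35 log units; beyond the scatter), the one step between compounds that differ in a single place, fluoro in place of hydrogen on an aromatic carbon.

Compound 4 `COc1cc2c(Oc3ccc(NC(=O)c4nn(-c5cccc(F)c5)c(=O)c5ccccc45)cc3F)ccnc2cc1OCCCN1CCC(C)CC1` is not yet measured. It differs from compound 3 by 3-fluorophenyl in place of 4-fluorophenyl on an aromatic nitrogen. Among the measured compounds shown here, no measured step covers this exact change. Compound 1 carries the same 3-fluorophenyl as compound 4 on a different amine and its value sits within the scatter of compound 3, so nothing here points to a shift beyond the scatter in this assay. The expectation for compound 4 is therefore a step of a 1.2-fold higher number from compound 3 to compound 4 (0.08 log units; within the scatter), that is, essentially none. Compound 4 is estimated at 800 nM, in the range 400 nM to 1600 nM.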

Compound 4, half-maximal inhibitory concentration: 860 nM
Compound 4: middle estimate off by 1.1-fold (0.03 log units), on the low side; low and high end bracket the measured number.
By their numbers in this assay, from the lowest: compounds 3, 4, 1 and 2 (each within the scatter of the next, the first and the last beyond it).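

In this assay, 3-fluorophenyl in place of 4-fluorophenyl on the aromatic nitrogen gives a 1.3-fold higher number from compound 3 to compound 4 (0.11 log units; within the scatter) and so does not separate the two isomers at this position. Set against the unsubstituted phenyl, 3-fluorophenyl gives a 1.7-fold lower number from compound 2 to compound 4 (0.24 log units; within the scatter) and stays within the scatter, whereas 4-fluorophenyl gives a 2.2-fold lower number from compound 2 to compound 3 (0.35 log units; beyond the scatter) and lies just beyond it. With 3-fluorophenyl in place, the amine change gives a 1.0-fold lower number from compound 1 to compound 4 (0.01 log units; within the scatter) and shows no separation between 4-methylpiperidin-1-yl and pyrrolidin-1-yl, and no supporting data bear on any of these results.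

Still open, from the compounds shown here alone, is whether a chloro or methoxy group on this phenyl would move the number beyond the scatter. Equally open, going by these compounds, is whether morpholin-4-yl in place of 4-methylpiperidin-1-yl would do so.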